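Toxicity of a Xanthine Base on the Shared Core

The source may report more compounds than this note shows. Statements on the series, on what has been measured and on what is new or still open speak of the compounds shown alone.

Compound 1 `CC(C)(C)[Si](C)(C)OC[C@H]1O[C@@H](n2cnc3cncnc32)[C@H](O[Si](C)(C)C(C)(C)C)[C@]12OS(=O)(=O)C=C2N` gives 13000 nM in a functional assay on MT4 cells (Homo sapiens) for cytotoxicity; on this read-out higher numbers stand for lower toxicity in this test and lower numbers for higher toxicity in this test.
Compound 2 `CC(C)(C)[Si](C)(C)OC[C@H]1O[C@@H](n2cnc3c(O)ncnc32)[C@H](O[Si](C)(C)C(C)(C)C)[C@]12OS(=O)(=O)C=C2N` gives 14000 nM in this assay.
Compound 3 `CC(C)(C)[Si](C)(C)OC[C@H]1O[C@@H](n2cnc3c(N)ncnc32)[C@H](O[Si](C)(C)C(C)(C)C)[C@]12OS(=O)(=O)C=C2N` gives 13000 nM in this assay.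

In this assay compound 3 sits level with compound 1 at the digits given, and the two together are the lowest of the three numbers; compound 2 stands only a 1.1-fold lower number from compound 2 to compound 3 (0.03 log units; within the scatter) away, which is within the scatter. Compound 4 `CC(C)(C)[Si](C)(C)OC[C@H]1O[C@@H](n2c(=O)[nH]c(=O)c3[nH]cnc32)[C@H](O[Si](C)(C)C(C)(C)C)[C@]12OS(=O)(=O)C=C2N` carries a group of 11 heavy atoms (5 carbon, 4 nitrogen, 2 oxygen; one five-membered aromatic ring with 2 hetero atoms, one six-membered aromatic ring with 2 hetero atoms) in place of a group of 10 heavy atoms (5 carbon, 5 nitrogen; one five-membered aromatic ring with 2 hetero atoms, one six-membered aromatic ring with 2 hetero atoms), on a saturated ring carbon. The measured steps that touch the same part of the molecule, a 1.1-fold higher number from compound 1 to compound 2 (0.03 log units; within the scatter) and no change at the digits printed from compound 1 to compound 3 (within the scatter), were both within the scatter, so swapping one small group for another on this aromatic system has not moved the read-out so far. Among the measured compounds shown here, the present change is larger, replacing the whole two-ring group, but no measured step speaks against the pattern seen in compounds 1, 2 and 3. The expectation is therefore a step of about no change at the digits printed from compound 3 to compound 4 (within the scatter), that is, none beyond the scatter. Compound 4 is thus estimated at 13000 nM, with a range from 6000 nM to 30000 nM.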

Compound 4, half-maximal cytotoxic concentration: 14000 nM
Compound 4: middle estimate off by 1.1-fold (0.03 log units), on the low side; the measured number falls inside the stated range.
By their numbers in this assay, from the lowest: compounds 1, 3, 2 and 4 (each within the scatter of the next).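

Even exchanging the whole two-ring group on the saturated ring carbon, with 2 double bonds outside aromatic rings entering, leaves no readable shift in this assay: the steps are a 1.1-fold higher number from compound 3 to compound 4 (0.03 log units; within the scatter), no change at the digits printed from compound 2 to compound 4 (within the scatter) and a 1.1-fold higher number from compound 1 to compound 4 (0.03 log units; within the scatter). The flat picture from the small swaps therefore also holds for this larger exchange, and none of the four compounds goes against it. Nothing available here explains why the read-out stays flat at this position.

Still open, going by these compounds, is whether a two-ring group carrying a carboxylic acid or a longer alkyl chain would stay level with these four compounds. All four also share one core, so these numbers cannot say whether the same flatness would appear on a different one.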